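Swapping the amide substituent: cyclopropyl to benzyl

The source may hold more compounds than are shown below. What is called first, only, known or untested is meant among the compounds shown, and "the series" means these compounds.

Compound 1 `Nc1sc(-c2ccccc2)c(-c2ccc(Cl)cc2)c1C(=O)NC1CC1` gives 17100 nM in a functional assay on PC-3 cells (Homo sapiens) for cytotoxicity, read by sulforhodamine B assay, with a stated time of 72 h; a lower number here means a stronger inhibitor, a higher number a weaker inhibitor.
Compound 2 `Nc1sc(-c2ccc(F)cc2)c(-c2ccc(Cl)cc2)c1C(=O)NC1CC1` gives 28000 nM in this assay.

Compound 2 holds the higher of the two numbers, but the step of a 1.6-fold higher number from compound 1 to compound 2 (0.21 log units; within the scatter) lies within the scatter, so the two cannot be told apart. Compound 3 `Nc1sc(-c2ccc(F)cc2)c(-c2ccc(Cl)cc2)c1C(=O)NCc1ccccc1` differs from compound 2 by benzyl in place of cyclopropyl on an amide-type nitrogen. Among the compounds with values here, the only measured step, a 1.6-fold higher number from compound 1 to compound 2 (0.21 log units; within the scatter), concerns a different place on the molecule, so no measured comparison bears on this change. A step of no clear size, a 1.3-fold lower number from compound 2 to compound 3 (0.10 log units; within the scatter), is therefore expected, with wide uncertainty. Compound 3 is estimated at 22000 nM, between 6000 nM and 80000 nM.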

Compound 3, half-maximal inhibitory concentration: 25800 nM
Beside the measured number, compound 3's estimate is 1.2-fold (0.07 log units) below it; the measured number falls inside the stated range.
By their numbers in this assay, from the lowest: compounds 1, 3 and 2 (each within the scatter of the next).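

On an amide-type nitrogen, benzyl in place of cyclopropyl gives a 1.1-fold lower number from compound 2 to compound 3 (0.04 log units; within the scatter) in this assay, so the two groups cannot be told apart here. Within the data shown here, the earlier step concerned only a fluoro on an aromatic carbon, so this is the first reading at the amide-type nitrogen. Nothing measured offers an explanation for this result.

On these data alone, whether a longer chain such as phenylethyl, or a benzyl carrying an amine or a carboxylic acid, would move the number at this nitrogen remains open. So does whether benzyl gives the same result without the fluoro.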